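The source may hold more compounds than are shown below. What is called first, only, known or untested is meant among the compounds shown, and "the series" means these compounds.

Compound 1 `Cc1ccc2nc(C(=O)Nc3c(F)cc(-c4cccc(F)c4)cc3F)c(C)c(C(=O)O)c2c1` and compound 2 `CCOc1ccc2nc(C(=O)Nc3c(F)cc(-c4cccc(F)c4)cc3F)c(C)c(C(=O)O)c2c1` share one core and differ in a single group on an aromatic carbon. In a functional assay on Hep 3B2 cells (Homo sapiens) for antiproliferative activity, read by MTT assay, with a stated time of 24 h, tested at 0.01 ug/mL (a higher number here means a stronger effect of the compound at the concentration tested, a lower number a weaker effect), compound 1 gives 0.36%, and compound 2 gives -0.12%. Going by the values given here, of the two numbers, compound 2 holds the smaller one, yet its only neighbour, compound 1, sits within the scatter of it, so the two cannot be told apart. That exchange, ethoxy in place of methyl on an aromatic carbon, gave a number 0.5 percentage points lower from compound 1 to compound 2 (within the scatter). Compound 3 `COc1ccc2nc(C(=O)Nc3c(F)cc(-c4cccc(F)c4)cc3F)c(C)c(C(=O)O)c2c1` takes the change one bond further out: hydrogen in place of methyl on a saturated chain carbon bound to an oxygen on an aromatic ring, so that ethoxy becomes methoxy. Among the compounds with values here, the only measured step touching this place is the one from compound 1 to compound 2, which stayed within the scatter despite swapping a whole group. For compound 3 the expected step is therefore a number 0.2 percentage points higher from compound 2 to compound 3 (within the scatter), nothing beyond the scatter. In this assay compound 3 is estimated at 0.1%, within a range from -5% to 6%.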

Compound 3, a percentage reported as inhibition, at one concentration (the size of the read-out at that concentration, not a potency): -0.68%
Beside the measured number, compound 3's estimate is 0.8 percentage points above it, within the range that was stated.
By their numbers in this assay, from the lowest: compounds 3, 2 and 1 (each within the scatter of the next).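

Shortening ethoxy to methoxy gave a number 0.6 percentage points lower from compound 2 to compound 3 (within the scatter), and methoxy in place of methyl gave a number 1 percentage points lower from compound 1 to compound 3 (within the scatter). So the earlier finding no longer rests on a single pair: in this assay, methyl, ethoxy and methoxy on this aromatic carbon cannot be told apart, whether the chain on the oxygen is changed or the whole group is swapped. No measured evidence is available to explain this flat result.

As far as these compounds go, all three compounds read close to zero at one single concentration, so it remains open whether the same group changes would separate at a higher concentration, where the effect is larger. From the compounds shown here alone, it is also open whether a longer chain such as propoxy, an amine or a chlorine atom on this aromatic carbon would give a number beyond the scatter.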